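A Methoxy for a Chloro on Compound 1

The source may hold more compounds than are shown below. What is called first, only, known or untested is meant among the compounds shown, and "the series" means these compounds.

Compound 1 `Cc1nc(-c2ccc(Cl)cc2)sc1C(=O)CSc1nc(N)c(C#N)c(-c2ccc(Cl)cc2)n1` is a molecule in which two aromatic rings each carry a chloro group. In an assay on membranes from CHO cells for displacement of a labelled ligand from adenosine receptor A1 (Homo sapiens), read by scintillation counting, with a stated time of 60 min, tested at 1 uM (on this read-out higher numbers stand for more inhibition at the one concentration tested (going by the name of the read-out) and lower numbers for less inhibition), compound 1 gives -3.7%. Among the three measured compounds this is the smallest number, but the gaps are modest: compound 2 `COc1ccc(-c2nc(C)c(C(=O)CSc3nc(N)c(C#N)c(-c4ccc(Cl)cc4)n3)s2)cc1` gives 1.1%, and compound 3 `COc1ccc(-c2nc(C)c(C(=O)CSc3nc(-c4ccc(OC)c(OC)c4)c(C#N)c(=O)[nH]3)s2)cc1` gives 2.5%, so none of the three stands apart from the others beyond the usual scatter.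

Compound 4 `COc1ccc(-c2nc(SCC(=O)c3sc(-c4ccc(Cl)cc4)nc3C)nc(N)c2C#N)cc1` differs from compound 1 in a single spot: methoxy in place of chloro on an aromatic carbon. This is the same kind of swap already seen once, though at the other chloro-bearing ring of the molecule. That measured swap gave a number 4.8 percentage points higher from compound 1 to compound 2 (within the scatter), a change too small to count as a real shift.

For the measured compounds named here, only this one step bears on the question, and it points to no movement beyond the scatter. The change from compound 1 to compound 4 in this assay is therefore expected to be small, a number 4.7 percentage points higher from compound 1 to compound 4 (within the scatter). Compound 4 is estimated to give 1%, within a range from -8% to 10%.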

Compound 4, a percentage reported as inhibition, at one concentration (the size of the read-out at that concentration, not a potency): 1.2%
Beside the measured number, compound 4's estimate is 0.2 percentage points below it; the range from low to high includes it.
By their numbers in this assay, from the lowest: compounds 1, 2, 4 and 3 (each within the scatter of the next).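

Read in this assay, the swap at this second chloro-bearing ring gives a number 4.9 percentage points higher from compound 1 to compound 4 (within the scatter), so the same change has now been seen at both rings of compound 1, and the earlier step, a number 4.8 percentage points higher from compound 1 to compound 2 (within the scatter), is likewise no larger than the scatter. The result therefore does not depend on which of the two rings carries the methoxy, at least for these two single swaps, and compound 4 at 1.2% remains close to zero inhibition, as do the other compounds shown. No measurement at hand offers an explanation for these numbers.

Since all these numbers lie so close to zero at the one concentration tested, they cannot show whether either ring position would respond to a change in a compound with clear inhibition. Going by these compounds, whether an amine, a carboxylic acid or a longer chain such as ethoxy in place of the chloro on this ring would shift the number remains open, as does the effect of such groups at the other ring.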